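The source may report more compounds than this note shows. Statements on the series, on what has been measured and on what is new or still open speak of the compounds shown alone.

Measured so far, in a functional assay on MCF7 cells (Homo sapiens) for cytotoxicity, read by MTT assay, with a stated time of 72 h; on this read-out higher numbers stand for weaker inhibition and lower numbers for stronger inhibition: compound 1 `COc1cc2ncnc(NNC(=S)NC(=O)c3ccc(C(F)(F)F)cc3)c2cc1OC` gives 16800 nM; compound 2 `COc1cc2ncnc(NNC(=S)NC(=O)c3ccccc3C)c2cc1OC` gives 19300 nM; compound 3 `O=C(NC(=S)NNc1ncnc2ccccc12)c1ccc(Cl)cc1` gives 5960 nM.

Compound 1 holds the second highest of the three numbers. Compound 2 sits within the scatter of it, while compound 3 shows a lower number, beyond the scatter. Compound 4 `COc1cc2ncnc(NNC(=S)NC(=O)c3ccccc3OC)c2cc1OC` keeps the core of compound 1 and changes one group: 2-methoxyphenyl in place of 4-(trifluoromethyl)phenyl on a carbonyl carbon. Going by the values given here, the only measured step that bears on this place is a 1.1-fold higher number from compound 1 to compound 2 (0.06 log units; within the scatter), which also swapped the ring on the carbonyl carbon. On that basis, compound 4 is expected to show no step beyond the scatter, a 1.1-fold higher number from compound 1 to compound 4 (0.03 log units; within the scatter). Compound 4 is therefore estimated at 18000 nM, with a range from 8000 nM to 40000 nM.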

Compound 4, half-maximal inhibitory concentration: 8800 nM
Beside the measured number, compound 4's estimate is 2.0-fold (0.31 log units) above it, within the range that was stated.
By their numbers in this assay, from the lowest: compounds 3, 4, 1 and 2 (each within the scatter of the next, the first and the last beyond it).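

In this assay, going by these compounds alone, methoxy in place of methyl on an aromatic carbon gives the first step at this position that lies beyond the scatter (a 2.2-fold lower number from compound 2 to compound 4 (0.34 log units; beyond the scatter)), though it is modest. Within the data shown here, measured against the 4-(trifluoromethyl)phenyl group, the 2-methoxyphenyl group stays within the scatter (a 1.9-fold lower number from compound 1 to compound 4 (0.28 log units; within the scatter)), so only one of the two comparisons shows a real difference. Nothing measured here explains this difference. On these data alone, whether an amine, a carboxylic acid or a longer chain such as ethoxy in place of the methoxy would lower the number further remains open.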